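The source may report more compounds than this note shows. Statements on the series, on what has been measured and on what is new or still open speak of the compounds shown alone.

In a functional assay on A498 cells (Homo sapiens) for cytotoxicity, read by sulforhodamine B assay, with a stated time of 48 h, tested at 0.1 uM (on this read-out higher numbers stand for a weaker effect at the one concentration tested and lower numbers for a stronger effect), compound 3 `COc1ccc(C(=O)/C=C/c2cc(-c3cc(OC)c(OC)c(OC)c3)n[nH]2)cc1` gives 87%, the highest of the three numbers in hand, though the others lie within the scatter of it. Compound 2 `COc1ccc(C(=O)/C=C/c2cc(-c3cc(OC)c(OC)c(OC)c3)n[nH]2)cc1OC` gives 86%, and compound 1 `COc1cc(-c2cc(/C=C/C(=O)c3ccc(N)cc3)[nH]n2)cc(OC)c1OC` gives 85%. The steps between them were all small: a number 1 percentage points higher from compound 1 to compound 2 (within the scatter), a number 2 percentage points higher from compound 1 to compound 3 (within the scatter) and a number 1 percentage points higher from compound 2 to compound 3 (within the scatter). Compound 4 `COc1cc(-c2cc(/C=C/C(=O)c3ccc(F)c(F)c3)[nH]n2)cc(OC)c1OC` differs from compound 3 in one place: 3,4-difluorophenyl in place of 4-methoxyphenyl on a carbonyl carbon. The step of a number 1 percentage points higher from compound 1 to compound 2 (within the scatter) also exchanged the group on the carbonyl carbon and stayed within the scatter, so no step beyond the scatter is expected in this assay for compound 4. The step of a number 1 percentage points lower from compound 3 to compound 4 (within the scatter) is therefore expected to be flat. Compound 4 is estimated at 86%, between 72% and 98%.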

Compound 4, a percentage reported as activity, at one concentration (the size of the read-out at that concentration, not a potency): 96%
For compound 4 the middle estimate is 10 percentage points below the measured one; measured number inside the range.
By their numbers in this assay, from the lowest: compounds 1, 2, 3 and 4 (each within the scatter of the next, the first and the last beyond it).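

Among these compounds, at the carbonyl carbon, the exchange now gives the first step beyond the scatter in this assay: a number 11 percentage points higher from compound 1 to compound 4 (beyond the scatter), so this position is not flat for every pair of groups. The same 3,4-difluorophenyl group stays within the scatter against both methoxy-bearing rings, with a number 9 percentage points higher from compound 3 to compound 4 (within the scatter) and a number 10 percentage points higher from compound 2 to compound 4 (within the scatter), so only the comparison with 4-aminophenyl clears it. Nothing at hand explains this difference. From the compounds shown here alone, how a 4-fluorophenyl group or a 4-carboxyphenyl group on the carbonyl carbon would read remains open.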